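Methoxycarbonyl to ethoxycarbonyl on the phenol analogue

The source may hold more compounds than are shown below. What is called first, only, known or untested is meant among the compounds shown, and "the series" means these compounds.

Three compounds on one shared core have been run in a functional assay on HeLa cells (Homo sapiens) for antiproliferative activity, read by MTT assay, with a stated time of 48 h; a higher number here means a weaker inhibitor of growth, a lower number a stronger inhibitor of growth. Compound 1 `COC(=O)N1N=C(c2cccc(OC)c2)CC1c1cc(OC)c(OC)c(OC)c1` gives 1530 nM. Compound 2 `CCOC(=O)N1N=C(c2cccc(OC)c2)CC1c1cc(OC)c(OC)c(OC)c1` carries the change methyl in place of hydrogen on a saturated chain carbon bound to an oxygen next to a carbonyl group relative to compound 1; in this assay compound 2 gives 4110 nM, and the step is a 2.7-fold higher number from compound 1 to compound 2 (0.43 log units; beyond the scatter). Compound 3 `COC(=O)N1N=C(c2cccc(O)c2)CC1c1cc(OC)c(OC)c(OC)c1` gives 1970 nM; against compound 1 the step is a 1.3-fold higher number from compound 1 to compound 3 (0.11 log units; within the scatter), so these two values are read as equivalent.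

Compound 4 `CCOC(=O)N1N=C(c2cccc(O)c2)CC1c1cc(OC)c(OC)c(OC)c1` has not yet been measured in this assay. It differs from compound 3 by methyl in place of hydrogen on a saturated chain carbon bound to an oxygen next to a carbonyl group. This is the same change already made from compound 1 to compound 2, and the place is described in the same words for both pairs; the change occurs twice among the four compounds. The cores on which it is made differ from each other by hydrogen in place of methyl on an oxygen on an aromatic ring, a change that on its own did not move the number beyond the scatter.

Among the measured compounds shown here, only one earlier instance of the change exists, so the expectation rests on it alone. Given the step seen from compound 1 to compound 2 of a 2.7-fold higher number from compound 1 to compound 2 (0.43 log units; beyond the scatter), the expected step for compound 4 is a 2.7-fold higher number from compound 3 to compound 4 (0.43 log units; beyond the scatter). Compound 4 is therefore estimated at 5300 nM in this assay, with an expected range from 2600 nM to 11000 nM, kept wide since a single prior step is the only basis.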

Compound 4, concentration for 50% growth inhibition: 3280 nM
For compound 4 the middle estimate is 1.6-fold (0.21 log units) above the measured one, and the stated range covers the measured number.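

In this assay the change from methoxycarbonyl to ethoxycarbonyl on the core of compound 3 gives a 1.7-fold higher number from compound 3 to compound 4 (0.22 log units; within the scatter), and this step does not differ from the one seen on the core of compound 1: the same change on two cores in this assay, a 2.7-fold higher number (0.43 log units; beyond the scatter) from compound 1 to compound 2 and a 1.7-fold higher number (0.22 log units; within the scatter) from compound 3 to compound 4, 1.6-fold (0.21 log units) apart, within the scatter of two such steps

The other single change in the set also reads alike on both sides, with hydrogen in place of methyl on an oxygen on an aromatic ring giving a 1.3-fold lower number from compound 2 to compound 4 (0.10 log units; within the scatter) when ethoxycarbonyl is present: the same change on two cores in this assay, a 1.3-fold higher number (0.11 log units; within the scatter) from compound 1 to compound 3 and a 1.3-fold lower number (0.10 log units; within the scatter) from compound 2 to compound 4, 1.6-fold (0.21 log units) apart, within the scatter of two such steps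

The four compounds therefore give no sign that either change depends on the other, but they do not establish a real effect of ethoxycarbonyl on the core of compound 3, where the step taken alone stays within the scatter, and two pairs in one assay cannot support a rule for other cores.

Still open, from the compounds shown here alone, is how a longer chain, such as propoxycarbonyl, or a branched one, such as isopropoxycarbonyl, would read on these two cores. Also open, going by these compounds, is whether the step from methoxycarbonyl to ethoxycarbonyl would hold with an amine or a carboxylic acid on the aromatic ring in place of the methoxy or hydroxy group.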